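Aryl-acetamide swap on the shared core: a third variant

A few compounds are considered here, and "the series" means these few. Any claim that something is new, unique, unknown or untested is made for them only; others in the source may bear on it.

Compound 2 `CCOc1ncc(-c2nc(C(F)(F)F)sc2N2CCN(C(=O)Cn3ncc4cccnc43)[C@H](C)C2)cn1` gives 55 nM in a functional assay on U2OS cells for antagonist activity at C-X-C chemokine receptor type 3 (Homo sapiens), read by beta-arrestin recruitment; a higher number here means a weaker inhibitor, a lower number a stronger inhibitor. Among the two compounds measured it carries the highest number, with compound 1 `CCOc1ncc(-c2nc(C(F)(F)F)sc2N2CCN(C(=O)Cn3ccc4cccnc43)[C@H](C)C2)cn1` nearest at 47 nM; the two lie within the scatter of each other, so no order between them is claimed. Going by the values given here, the one change measured so far, a 1.2-fold higher number from compound 1 to compound 2 (0.07 log units; within the scatter), exchanged one bicyclic group for another on the saturated chain carbon bound to the carbonyl carbon and left the number essentially where it was.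

Compound 3 `CCOc1ncc(-c2nc(C(F)(F)F)sc2N2CCN(C(=O)Cn3c(=O)oc4ccccc43)[C@H](C)C2)cn1` alters the same position again: a group of 10 heavy atoms (7 carbon, 1 nitrogen, 2 oxygen; one five-membered aromatic ring with 2 hetero atoms, one six-membered aromatic ring of carbon only) in place of a group of 9 heavy atoms (6 carbon, 3 nitrogen; one five-membered aromatic ring with 2 hetero atoms, one six-membered aromatic ring with 1 hetero atom), on a saturated chain carbon bound to a carbonyl carbon. The step from compound 1 to compound 2 is the only one that bears on this, and it was within the scatter; the entering group, with its six-membered aromatic ring of carbon only and its double bond outside aromatic rings, is a larger departure than that earlier swap, so a somewhat wider spread is allowed for. The expected step in this assay is a 1.5-fold higher number from compound 2 to compound 3 (0.16 log units; within the scatter), that is, small and not clearly beyond the scatter. For compound 3 the estimate in this assay is 80 nM, with a range from 30 nM to 250 nM.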

Compound 3, half-maximal inhibitory concentration: 99 nM
For compound 3 the middle estimate is 1.2-fold (0.09 log units) below the measured one, within the range that was stated.
By their numbers in this assay, from the lowest: compounds 1, 2 and 3 (each within the scatter of the next, the first and the last beyond it).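

In this assay, the position on a saturated chain carbon bound to a carbonyl carbon now shows its first step beyond the scatter, a 2.1-fold higher number from compound 1 to compound 3 (0.32 log units; beyond the scatter), a modest one, with an entering group that has a six-membered aromatic ring of carbon only and a double bond outside aromatic rings. Against the other bicyclic group the same entering group gives a 1.8-fold higher number from compound 2 to compound 3 (0.26 log units; within the scatter), which stays within the scatter even though the counts of hydrogen-bond donors and acceptors are the same in the leaving and entering groups, so the position accepts all three bicyclic groups shown with only a small loss, and that loss is readable against one of the two comparators alone. Nothing at hand explains the difference.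

Still open, going by these compounds, is whether this position needs a bicyclic group at all, since a single phenyl ring, an amine or a carboxylic acid on the same chain carbon would each test that. Also open, on these data alone, is whether the modest step holds when the shared core changes elsewhere, for instance with a nitrile in place of the trifluoromethyl group.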